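Butoxycarbonyl on the fluoro chloro series: compound 1 to compound 4

The source may hold more compounds than are shown below. What is called first, only, known or untested is meant among the compounds shown, and "the series" means these compounds.

In a functional assay on the whole organism for inhibition, with Scenedesmus acutus as the target (on this read-out lower numbers stand for stronger inhibition and higher numbers for weaker inhibition), compound 1 `O=C1C2=C(CCCC2)C(=O)N1c1ccc(Cl)cc1F` gives 37.2 nM. Compound 2 `CCCOC(=O)c1cc(N2C(=O)C3=C(CCCC3)C2=O)c(F)cc1Cl` gives 33.1 nM, which lies within the scatter of compound 1. Compound 3 `CCCCOC(=O)c1cc(N2C(=O)C3=C(CCCC3)C2=O)ccc1Cl` gives 6310 nM, the highest number of the three and far from the other two.

Compound 4 `CCCCOC(=O)c1cc(N2C(=O)C3=C(CCCC3)C2=O)c(F)cc1Cl` has not yet been measured. Its change from compound 1 is butoxycarbonyl in place of hydrogen on an aromatic carbon. The new group stands ortho to a chloro group, meta to a large group and para to a fluoro group.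

Going by the values given here, the one measured step that bears directly on this change is a 1.1-fold lower number from compound 1 to compound 2 (0.05 log units; within the scatter), for propoxycarbonyl in the same place. That step is small, and compound 4 differs from compound 2 only by the name of the ester chain. Compound 3 also carries butoxycarbonyl but has no fluoro group, and its 6310 nM is therefore a weaker guide, though it leaves the upper end of the range open. No step beyond the scatter is expected in this assay.

The expected step is a 1.1-fold higher number from compound 1 to compound 4 (0.03 log units; within the scatter). The estimated value for compound 4 is 40 nM, with an expected range of 12 nM to 150 nM.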

Compound 4, half-maximal inhibitory concentration: 126 nM
The estimate for compound 4 lay 3.2-fold (0.50 log units) below the measured number; measured number inside the range.
By their numbers in this assay, from the lowest: compounds 2 and 1 (each within the scatter of the next); then compound 4; then compound 3.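

In this assay this position proves sensitive to the length of the ester chain: propoxycarbonyl left the number unchanged within the scatter, whereas butoxycarbonyl gives a 3.4-fold higher number from compound 1 to compound 4 (0.53 log units; beyond the scatter), and the methyl that separates the two chains alone accounts for a 3.8-fold higher number from compound 2 to compound 4 (0.58 log units; beyond the scatter). The fluoro group matters far more in the presence of butoxycarbonyl, with a 50-fold lower number from compound 3 to compound 4 (1.70 log units; beyond the scatter), so the high number of compound 3 cannot be read as the effect of the butoxycarbonyl group alone, and compound 4 stays much closer to compound 1 than to compound 3. No measurement at hand offers a reason for either step.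

The compounds shown leave open whether a longer chain such as pentyloxycarbonyl raises the number further, and whether a carboxylic acid or a shorter methoxycarbonyl at the same place falls in line with the two esters. Also open, going by these compounds, is whether the fluoro step keeps its size with propoxycarbonyl in place of butoxycarbonyl, or with hydrogen at that position.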